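Para-substituted aryl ureas on rice: heptyl to fluoro

The compounds below may be only part of what the source reports. "The series", "measured", "known", "first", "only" and "open" are said of these compounds alone.

Measured so far:
compound 1, `CC(C)c1ccc(NC(=O)N[C@H](C)c2ccccc2)cc1`, 99%
compound 2, `CCCCCCCc1ccc(NC(=O)N[C@H](C)c2ccccc2)cc1`, 100%

In an ADME assay on the whole organism with Oryza sativa as the target, tested at 0.1 uM (on this read-out higher numbers stand for a weaker effect at the one concentration tested and lower numbers for a stronger effect), compound 1 gives 99%. Going by the values given here, compound 2, `CCCCCCCc1ccc(NC(=O)N[C@H](C)c2ccccc2)cc1`, gives 100% in this assay and so holds the higher of the two numbers, though its only neighbour, compound 1, lies within the scatter of it: the two values show no order. Among the compounds with values here, the one step that has been measured, a number 1 percentage points higher from compound 1 to compound 2 (within the scatter), swaps one alkyl group for another on the same aromatic carbon and leaves the read-out essentially unchanged.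

Compound 3, `C[C@@H](NC(=O)Nc1ccc(F)cc1)c1ccccc1`, is not yet measured. Its change from compound 2 is fluoro in place of heptyl on an aromatic carbon. Within the data shown here, the single measured step bears on it only loosely, since it kept the read-out flat while the group on that carbon changed. On that basis compound 3 is expected to show a number 2 percentage points lower from compound 2 to compound 3 (within the scatter), no step beyond the scatter. Compound 3 is therefore estimated at 98%, with a range of 87% to 100%.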

Compound 3, a percentage reported as activity, at one concentration (the size of the read-out at that concentration, not a potency): 98%
Estimate against measurement, compound 3: no gap at the digits printed; low and high end bracket the measured number.
By their numbers in this assay, from the lowest: compounds 3, 1 and 2 (each within the scatter of the next).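

In this assay, fluoro in place of heptyl on this aromatic carbon, para to a large group, gives a number 2 percentage points lower from compound 2 to compound 3 (within the scatter), and fluoro in place of isopropyl gives a number 1 percentage points lower from compound 1 to compound 3 (within the scatter). Going by these compounds alone, the earlier pair showed only that one alkyl group could replace another here without a step beyond the scatter; these results extend that to a change from alkyl to fluoro, so this read-out at its one concentration does not separate isopropyl, heptyl and fluoro at this position. Nothing available here accounts for this flat result.

From the compounds shown here alone, whether an amine, a carboxylic acid or a nitrile on the same carbon would give a step beyond the scatter remains open. So does whether any change to this position would produce a clearly stronger effect at the concentration tested.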